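Shortening a Saturated Chain on Two Different Cores

A few compounds are considered here, and "the series" means these few. Any claim that something is new, unique, unknown or untested is made for them only; others in the source may bear on it.

Three compounds have been measured in a functional assay on A549 cells (Homo sapiens) for inhibition, read by MTT assay; a lower number here means a stronger inhibitor, a higher number a weaker inhibitor:

compound 1 `CCCCCCCCn1cc(/C=C/C(=O)c2ccc(NC(=O)CN3CCN(C(=O)OC(C)(C)C)CC3)cc2)nn1`: 43300 nM
compound 2 `CCCCCCCCCCn1cc(/C=C/C(=O)c2ccc(NC(=O)CN3CCC(Cc4ccccc4)CC3)cc2)nn1`: 67700 nM
compound 3 `CCCCCCCCCCn1cc(/C=C/C(=O)c2ccc(NC(=O)CN3CCN(C(=O)OC(C)(C)C)CC3)cc2)nn1`: 45400 nM

Compound 3 and compound 1 differ in a single place, (hydrogen in place of ethyl on a saturated chain carbon, eight bonds along the chain from an aromatic nitrogen). Across this change the number moved by a 1.0-fold lower number from compound 3 to compound 1 (0.02 log units; within the scatter), so the chain shortening left the read-out essentially where it was.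

Compound 2 carries the longer chain of compound 3 but a different core; the difference between the two cores is not broken down here. Their two values lie within the usual scatter of each other, so nothing more than that can be said of the core swap from these data.

Compound 4 `CCCCCCCCn1cc(/C=C/C(=O)c2ccc(NC(=O)CN3CCC(Cc4ccccc4)CC3)cc2)nn1` has not yet been measured. It differs from compound 2 by hydrogen in place of ethyl on a saturated chain carbon, eight bonds along the chain from an aromatic nitrogen, the same change and the same place as from compound 3 to compound 1. Because that earlier step gave a 1.0-fold lower number from compound 3 to compound 1 (0.02 log units; within the scatter), the step from compound 2 to compound 4 is expected to be a 1.0-fold lower number from compound 2 to compound 4 (0.02 log units; within the scatter). Compound 4 is therefore estimated at 65000 nM, with a likely range from 30000 nM to 140000 nM.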

Compound 4, half-maximal inhibitory concentration: 43800 nM
Compound 4: middle estimate off by 1.5-fold (0.17 log units), on the high side, and the stated range covers the measured number.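

On the core of compound 2, the chain shortening gave a 1.5-fold lower number from compound 2 to compound 4 (0.19 log units; within the scatter) in this assay, so there too the change left the read-out within the usual scatter. Set beside the earlier step, the change carried from one core to the other with no difference that these data can resolve: the same change on two cores in this assay, a 1.0-fold lower number (0.02 log units; within the scatter) from compound 3 to compound 1 and a 1.5-fold lower number (0.19 log units; within the scatter) from compound 2 to compound 4, 1.5-fold (0.17 log units) apart, within the scatter of two such steps

This shows that the change had no effect large enough to read on either core, so the agreement is one of two null steps rather than the transfer of a real effect; it does not show that the two steps are identical, or that the same would hold on a third core.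

The compounds shown leave open whether a much shorter chain, such as butyl, would move the number beyond the scatter. They also leave open whether an amine or a carboxylic acid in place of the saturated chain would do so on either core.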